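The compounds below may be only part of what the source reports. "The series", "measured", "known", "first", "only" and "open" are said of these compounds alone.

Working notes on the series.

Compound 1 `O=C(NCC1CCN(CCCS(=O)(=O)N2CCN(c3ccccn3)CC2)CC1)c1cccc2c1OCCO2` gives, in an assay on isolated protein for inhibition of 5-hydroxytryptamine receptor 4 (Homo sapiens) (on this read-out higher numbers stand for weaker inhibition and lower numbers for stronger inhibition), a value of 0.251 nM. Going by the values given here, compound 2 `CCN1CCN(S(=O)(=O)CCCN2CCC(CNC(=O)c3cccc4c3OCCO4)CC2)CC1` gives 0.0501 nM in this assay, the lowest of the two numbers so far; the only measured step, a 5.0-fold lower number from compound 1 to compound 2 (0.70 log units; beyond the scatter), is the one that separates them and it lies beyond the scatter.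

Compound 3 `O=C(NCC1CCN(CCCS(=O)(=O)N2CCOCC2)CC1)c1cccc2c1OCCO2` has not been measured. It differs from compound 2 by morpholin-4-yl in place of 4-ethylpiperazin-1-yl on a sulfonyl sulfur. Among the compounds with values here, no measured step alters the ring itself; the one step on record changed only what sits on the ring nitrogen, a 5.0-fold lower number from compound 1 to compound 2 (0.70 log units; beyond the scatter), and so bears on compound 3 only indirectly, as a sign that the end of this sulfonyl side chain matters to the read-out. Because that step, a 5.0-fold lower number from compound 1 to compound 2 (0.70 log units; beyond the scatter), showed that the group on the ring nitrogen contributes to the low number of compound 2, its removal together with the nitrogen is expected to cost something. For compound 3 the expected step is a 3.2-fold higher number from compound 2 to compound 3 (0.50 log units; beyond the scatter), a modest rise with wide uncertainty. Compound 3 is therefore estimated at 0.16 nM, with a range from 0.04 nM to 0.63 nM.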

Compound 3, inhibition constant: 0.398 nM
Estimate against measurement, compound 3: 2.5-fold (0.40 log units) below; the measured number falls inside the stated range.
By their numbers in this assay, from the lowest: compound 2; then compounds 1 and 3 (each within the scatter of the next).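

Replacing 4-ethylpiperazin-1-yl with morpholin-4-yl on the sulfonyl sulfur gives, in this assay, a 7.9-fold higher number from compound 2 to compound 3 (0.90 log units; beyond the scatter), so a change to the ring itself moves the number at this position, and by a step of similar order to the earlier change of the group on the ring nitrogen. Against the 4-(pyridin-2-yl)piperazin-1-yl of compound 1, the same morpholin-4-yl gives a 1.6-fold higher number from compound 1 to compound 3 (0.20 log units; within the scatter), so these two very different ring ends are not told apart, and among the three compounds only the 4-ethylpiperazin-1-yl of compound 2 stands apart from the others. No measurement on record accounts for this difference, and the numbers describe the change without explaining it.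

The step from compound 2 to compound 3 swaps the ethyl-bearing nitrogen for a ring oxygen in one move, so the shares of the ethyl group and of that nitrogen remain unseparated. Compounds carrying piperazin-1-yl with a free ring amine, 4-methylpiperazin-1-yl, 4-propylpiperazin-1-yl or piperidin-1-yl on the sulfonyl sulfur would divide that step and show how far a longer alkyl chain on the ring nitrogen is tolerated.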